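Shortening the acyl group from propanoyl to acetyl

This account rests on a few compounds, and the source may have more. Where it says the series, first, only, none or still open, it means among the compounds named here.

The measured compounds and their values:
compound 1, `O=C(Nc1cc(C(F)(F)F)cc(C(F)(F)F)c1)C1CCc2ccccc2N1C(=O)c1ccccc1Cl`, 4050 nM;
compound 2, `CCC(=O)N1c2ccccc2CCC1C(=O)Nc1ccccc1C(F)(F)F`, > 80000 nM;
compound 3, `CCCCCCCCC(=O)N1c2ccccc2CCC1C(=O)Nc1cc(C(F)(F)F)cc(C(F)(F)F)c1`, 4970 nM.

The three compounds were tested in a functional assay on HCT-15 cells (Homo sapiens) for cytotoxicity, read by sulforhodamine B assay, with a stated time of 72 h; on this read-out higher numbers stand for weaker inhibition of growth and lower numbers for stronger inhibition of growth. Compound 1 gives 4050 nM and compound 3 gives 4970 nM. For compound 2 only a limit of the assay is reported, > 80000 nM. This is the limit of > 80000 nM in this assay, at which 1 of the 3 values shown sits, so compound 2 stands at the weak end of what is shown, with no number attached.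

Compound 4, `CC(=O)N1c2ccccc2CCC1C(=O)Nc1ccccc1C(F)(F)F`, differs from compound 2 in one place: hydrogen in place of methyl on a saturated chain carbon bound to a carbonyl carbon, which read one bond further out is propanoyl to acetyl. For the measured compounds named here, no measured pair shares this change. Going by the values given here, the only measured step, a 1.2-fold higher number from compound 1 to compound 3 (0.09 log units; within the scatter), concerns a different group on the same kind of carbonyl carbon, and it stayed within the scatter. Compound 2 gives no number to move from, so compound 4 is expected to remain at or near the limit, and the step of a number no higher from compound 2 to compound 4 (the limit leaves the size open) is an estimate only. Compound 4 is therefore expected at 80000 nM, within 20000 nM to 200000 nM.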

Compound 4, concentration for 50% growth inhibition: > 80000 nM
Compound 4: only a limit was reported; the forecaster's own chance of this, stated with the estimate: 70%; the middle value sits exactly at the limit.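

No step can be read from compound 2 to compound 4 because each is reported only as a limit: the limit of > 80000 nM in this assay, at which 2 of the 4 values shown sit. The compounds shown leave open whether acetyl in place of propanoyl changes growth inhibition at all in a compound that gives a measurable number.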